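Trimming the Amine Substituent on the Shared Core

The source may hold more compounds than are shown below. What is called first, only, known or untested is meant among the compounds shown, and "the series" means these compounds.

Measured compounds in an assay on Sf9 cells for inhibition of activin receptor type-1 (Homo sapiens), read by HTRF, with a stated time of 3 h, in the presence of a further agent that is not named here; on this read-out lower numbers stand for stronger inhibition and higher numbers for weaker inhibition:
compound 1 `C[C@@H]1CN(c2ccc(-c3n[nH]c4cnc(N5CCCCC5)nc34)cn2)CCN1`: 40 nM
compound 2 `C[C@@H]1CN(c2ccc(-c3n[nH]c4cnc(N5[C@H](C)CNC[C@@H]5C)nc34)cn2)CCN1`: 793 nM

Compound 2 stands highest of the two numbers; its nearest neighbour is compound 1, and the step of a 20-fold higher number from compound 1 to compound 2 (1.30 log units; beyond the scatter) lies beyond the scatter. Compound 3 `CC1CCCCN1c1ncc2[nH]nc(-c3ccc(N4CCN[C@H](C)C4)nc3)c2n1` differs from compound 2 by 2-methylpiperidin-1-yl in place of 2,6-dimethylpiperazin-1-yl on an aromatic carbon. Among the measured compounds shown here, only one measured step bears on this change, and because a 20-fold higher number from compound 1 to compound 2 (1.30 log units; beyond the scatter) was large while compound 3 undoes part of that change, a drop in this assay is expected, roughly a 5.3-fold lower number from compound 2 to compound 3 (0.72 log units; beyond the scatter). Compound 3 is therefore estimated at 150 nM, within a range of 50 nM to 500 nM.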

Compound 3, half-maximal inhibitory concentration: 8.1 nM
Compound 3: the middle estimate sits 19-fold (1.27 log units) above what was measured, outside the stated range (below it).
By their numbers in this assay, from the lowest: compound 3; then compound 1; then compound 2.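

The swap to 2-methylpiperidin-1-yl gives a 98-fold lower number from compound 2 to compound 3 (1.99 log units; beyond the scatter) in this assay, and methyl in place of hydrogen on a saturated ring carbon gives a 4.9-fold lower number from compound 1 to compound 3 (0.69 log units; beyond the scatter). A single ring methyl on the piperidin-1-yl group therefore does not raise the number at this position, unlike the full change to 2,6-dimethylpiperazin-1-yl. Nothing available explains either step.

Going by these compounds, the second ring nitrogen and the second methyl change together between compound 2 and compound 3, so their separate contributions remain open. Either 2,6-dimethylpiperidin-1-yl or plain piperazin-1-yl at this position would begin to separate them.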